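The source may report more compounds than this note shows. Statements on the series, on what has been measured and on what is new or still open speak of the compounds shown alone.

Compound 2 `CC(C)=CCn1ccc2cc(/C(C)=C/C(=O)Nc3ccccc3OCCCC(=O)O)ccc21` is one of three measured compounds built on a shared core that differ only in the group on the aromatic nitrogen. In an assay on Prostate gland for inhibition of steroid 5-alpha-reductase (Rattus norvegicus) (a lower number here means a stronger inhibitor, a higher number a weaker inhibitor), compound 2 gives 120 nM, the same at the digits shown as compound 1 `CCCCCCCn1ccc2cc(/C(C)=C/C(=O)Nc3ccccc3OCCCC(=O)O)ccc21`, which gives 120 nM, so no change at the digits printed from compound 1 to compound 2 (within the scatter). Together they sit at the high end of the set. Compound 3 `CCCC(CC)n1ccc2cc(/C(C)=C/C(=O)Nc3ccccc3OCCCC(=O)O)ccc21` gives 9.3 nM, and the step of a 13-fold lower number from compound 2 to compound 3 (1.11 log units; beyond the scatter) shows that a branched 1-ethylbutyl on the aromatic nitrogen lowers the number considerably, whereas a 13-fold lower number from compound 1 to compound 3 (1.11 log units; beyond the scatter) tells the same story from the other unbranched chain.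

Compound 4 `COc1ccc(Cn2ccc3cc(/C(C)=C/C(=O)Nc4ccccc4OCCCC(=O)O)ccc32)cc1` carries a different kind of change: 4-methoxyphenyl in place of 2-methylprop-1-en-1-yl on a saturated chain carbon bound to an aromatic nitrogen. Within the data shown here, no measured step swaps a chain for an aromatic ring here, so the evidence is indirect. Exchanging one unbranched group for another left the number unchanged, and only branching at the carbon bound to the aromatic nitrogen moved it. A 4-methoxybenzyl is unbranched at that carbon, so compound 4 is expected to stay close to compound 2, with a 1.1-fold lower number from compound 2 to compound 4 (0.04 log units; within the scatter) judged to lie within the scatter. The estimate for compound 4 is 110 nM, within 35 nM to 350 nM.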

Compound 4, half-maximal inhibitory concentration: 480 nM
For compound 4 the middle estimate is 4.4-fold (0.64 log units) below the measured one, outside the stated range (above it).
By their numbers in this assay, from the lowest: compound 3; then compounds 1 and 2 (each within the scatter of the next); then compound 4.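

In this assay, the group on the aromatic nitrogen matters even without branching at the carbon bound to that nitrogen: 4-methoxybenzyl gives a 4.0-fold higher number from compound 2 to compound 4 (0.60 log units; beyond the scatter), and the same size of step appears as a 4.0-fold higher number from compound 1 to compound 4 (0.60 log units; beyond the scatter). Among these compounds, the two open-chain groups in compounds 1 and 2 had matched, so this is the first sign that an unbranched group at this place can still move the number, and here it moves upward. The range at this one place also widens, with a 52-fold higher number from compound 3 to compound 4 (1.71 log units; beyond the scatter). Nothing measured here explains the rise.

The compounds shown leave open whether the rise goes with the benzene ring itself or with its methoxy group, which a plain benzyl would help separate. They also leave open how a branched group carrying a ring, such as 1-phenylpropyl, would compare with 1-ethylbutyl.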